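The compounds below may be only part of what the source reports. "The series", "measured", "known", "first", "only" and "open" are said of these compounds alone.

For the measured compounds named here, compound 1 `Cc1cccc(/C=N/Nc2ncc3c(n2)n(C2CCCC2)c(=O)c(=O)n3C)c1` is one of two compounds measured in a functional assay on PC-3 cells (Homo sapiens) for antiproliferative activity, read by MTT assay (on this read-out lower numbers stand for stronger inhibition and higher numbers for weaker inhibition), where compound 1 gives 53600 nM. Going by the values given here, its only measured neighbour is compound 2 `Cn1c(=O)c(=O)n(C2CCCC2)c2nc(N/N=C/c3ccc(O)c(F)c3)ncc21`, which in this assay gives 85200 nM. The change between them is a 1.6-fold higher number from compound 1 to compound 2 (0.20 log units; within the scatter), so the two numbers cannot be told apart, and compound 1 stands with compound 2 at the same level as far as the data show.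

Compound 3 `Cn1c(=O)c(=O)n(C2CCCC2)c2nc(N/N=C/c3cccc([N+](=O)[O-])c3)ncc21` differs from compound 1 by nitro in place of methyl on an aromatic carbon. Among the compounds with values here, no measured step exchanges a methyl for a nitro, so the only comparison that bears on this step is the one from compound 1 to compound 2, where another group on the same aromatic ring was exchanged and the number moved only within the scatter. On this basis no step beyond the scatter is expected for compound 3 in this assay, with the step from compound 1 estimated at a 1.0-fold higher number from compound 1 to compound 3 (0.01 log units; within the scatter). Compound 3 is therefore expected to give about 55000 nM in this assay, with a range from 18000 nM to 170000 nM.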

Compound 3, half-maximal inhibitory concentration: 20300 nM
The estimate for compound 3 lay 2.7-fold (0.43 log units) above the measured number, and the stated range covers the measured number.
By their numbers in this assay, from the lowest: compound 3; then compounds 1 and 2 (each within the scatter of the next).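

In this assay, the group on this aromatic ring is now seen to matter: nitro in place of methyl, on an aromatic carbon meta to a large group, gives a step beyond the scatter (a 2.6-fold lower number from compound 1 to compound 3 (0.42 log units; beyond the scatter)), whereas the earlier exchange of 3-methylphenyl for 3-fluoro-4-hydroxyphenyl stayed within it (a 1.6-fold higher number from compound 1 to compound 2 (0.20 log units; within the scatter)). The 3-nitrophenyl group also stands apart from the 3-fluoro-4-hydroxyphenyl group (a 4.2-fold lower number from compound 2 to compound 3 (0.62 log units; beyond the scatter)), so compound 3 is the only one of the three whose steps to both others lie beyond the scatter, and it carries the lowest number, although both steps are modest. Nothing available accounts for these steps.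

The compounds shown leave open whether the lower number is particular to nitro or would also appear with another group at this place, such as a nitrile, an amine or a carboxylic acid. They also leave open whether nitro would give a similar step on a different carbon of the ring, and whether the step would hold on a core carrying something other than the cyclopentyl group.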